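A few compounds are considered here, and "the series" means these few. Any claim that something is new, unique, unknown or untested is made for them only; others in the source may bear on it.

Measured compounds:
compound 1 `CC(C)(C)c1ccc(C(=O)N2CCC3(CC2)C(=O)N(CC(=O)NCCC(=O)O)CN3c2ccccc2)cc1`, 11400 nM
compound 2 `CCC1CCCN(C(=O)CN2CN(c3ccccc3)C3(CCN(C(=O)c4ccc(C5CCCCC5)cc4)CC3)C2=O)C1`, 2600 nM
compound 3 `CC(C)(C)c1ccc(C(=O)N2CCC3(CC2)C(=O)N(CC(=O)N2CCCC(O)C2)CN3c2ccccc2)cc1`, 12200 nM

In an assay on HEK293 cells for displacement of a labelled ligand from NPC1-like intracellular cholesterol transporter 1 (Homo sapiens) (a higher number here means a weaker inhibitor, a lower number a stronger inhibitor), compound 3 gives 12200 nM, the highest of the three numbers; compound 1 sits closest to it, while compound 2 lies furthest away with its lower number. Going by the values given here, the one step that can be traced, a 1.1-fold higher number from compound 1 to compound 3 (0.03 log units; within the scatter), changes a group on the carbonyl carbon without leaving the scatter.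

Compound 4 `CCC1CCCN(C(=O)CN2CN(c3ccccc3)C3(CCN(C(=O)c4ccc(C(C)(C)C)cc4)CC3)C2=O)C1` is not yet measured. It differs from compound 3 by ethyl in place of hydroxy on a saturated ring carbon. Among the compounds with values here, no measured pair isolates this change: compound 2 carries the same 3-ethylpiperidin-1-yl group but also a different substituent on the benzoyl ring, so its value alone cannot be assigned to the ethyl. Within the data shown here, since the only single-point step on this side of the molecule stayed within the scatter, the expected step of a 1.9-fold lower number from compound 3 to compound 4 (0.27 log units; within the scatter) is modest and leans toward a lower number. Compound 4 is therefore estimated at 6500 nM, between 2500 nM and 16000 nM.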

Compound 4, half-maximal inhibitory concentration: 3900 nM
Compound 4: middle estimate off by 1.7-fold (0.22 log units), on the high side, and the stated range covers the measured number.
By their numbers in this assay, from the lowest: compounds 2 and 4 (each within the scatter of the next); then compounds 1 and 3 (each within the scatter of the next).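

In this assay, going by these compounds alone, ethyl in place of hydroxy on a saturated ring carbon gives a 3.1-fold lower number from compound 3 to compound 4 (0.50 log units; beyond the scatter), the first traced step on this side of the molecule to pass beyond the scatter. The 3-ethylpiperidin-1-yl group also separates from the (2-carboxyethyl)amino group on the carbonyl carbon, with a 2.9-fold lower number from compound 1 to compound 4 (0.47 log units; beyond the scatter), so this site responds to the group it carries, although 3-hydroxypiperidin-1-yl and (2-carboxyethyl)amino did not separate. With the ethyl group held constant, tert-butyl in place of cyclohexyl on an aromatic carbon gives a 1.5-fold higher number from compound 2 to compound 4 (0.18 log units; within the scatter), which stays within the scatter.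

The data shown offer no explanation for these differences. As far as these compounds go, whether a propyl chain or an amine on the same ring carbon would carry the number lower remains open.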